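The source may report more compounds than this note shows. Statements on the series, on what has been measured and on what is new or still open speak of the compounds shown alone.

Measured so far:
- compound 1 `CCC(CC)C(=O)Nc1c(C(O)(C(F)(F)F)C(F)(F)F)ccc2ccccc12`: 4340 nM
- compound 2 `O=C(Nc1c(C(O)(C(F)(F)F)C(F)(F)F)ccc2ccccc12)c1cccc(Br)c1`: 80 nM

Going by the values given here, in an assay on LtK cells with ATP-sensitive inward rectifier potassium channel 11 (Homo sapiens) as the target (on this read-out higher numbers stand for an effect only at larger amounts of compound and lower numbers for an effect already at smaller amounts), compound 2 gives the lower of the two numbers, and a 54-fold lower number from compound 1 to compound 2 (1.73 log units; beyond the scatter) separates it from compound 1, its only neighbour. Compound 3 `COc1cccc(C(=O)Nc2c(C(O)(C(F)(F)F)C(F)(F)F)ccc3ccccc23)c1` keeps the whole of compound 2 except one substituent: methoxy in place of bromo on an aromatic carbon, meta to a large group. Among the compounds with values here, the only measured step, from a pentan-3-yl to a 3-bromophenyl on the carbonyl carbon, concerns the exchange of the entire group on the carbonyl, not a single substituent on the aromatic ring, so it bears on the present change only loosely: it shows that the aryl amide is the potent type and suggests that compound 3, which retains that aryl amide, stays in the same region. Without a second ring-substituted aryl amide for comparison, the direction of a small shift cannot be read from these data. A modest rise in the number, a 2.5-fold higher number from compound 2 to compound 3 (0.40 log units; beyond the scatter), is expected for compound 3, about 200 nM with a range from 60 nM to 700 nM.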

Compound 3, half-maximal effective concentration: 185 nM
Compound 3: the middle estimate sits 1.1-fold (0.03 log units) above what was measured, within the range that was stated.
By their numbers in this assay, from the lowest: compound 2; then compound 3; then compound 1.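

Bromo and methoxy can both sit on this aromatic carbon, meta to a large group, and the exchange of bromo for methoxy gives a 2.3-fold higher number from compound 2 to compound 3 (0.36 log units; beyond the scatter). The position therefore responds to a change of substituent, but this one step is modest, while the exchange of pentan-3-yl for the whole 3-methoxyphenyl group gives a 23-fold lower number from compound 1 to compound 3 (1.37 log units; beyond the scatter) and so remains a large step, as it was with 3-bromophenyl. No measurement shown here explains why the number moves with this exchange.

Open, going by these compounds, is how this same carbon would respond to other groups, such as an amine, a carboxylic acid or a longer chain like ethoxy. Also open, on these data alone, is whether bromo or methoxy would give similar numbers on another carbon of the ring.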